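The compounds below may be only part of what the source reports. "The series", "measured", "known", "first", "only" and "open" are said of these compounds alone.

Working notes on the series around compound 1 `CCOC(=O)c1cnc(C)nc1NN1C(=O)C=C(C)C1=O`. Going by the values given here, in a functional assay on Jurkat cells for inhibition of nuclear factor NF-kappa-B complex (Homo sapiens) (a lower number here means a stronger inhibitor, a higher number a weaker inhibitor), compound 1 gives 16000 nM, the highest of the three numbers so far. Compound 2 `CCOC(=O)c1cnc(CC)nc1NN1C(=O)C=C(C)C1=O` gives 10000 nM in this assay, and compound 3 `CCOC(=O)c1cnc(SC)nc1NN1C(=O)C=C(C)C1=O` gives 200 nM.

Compound 4 `CCOC(=O)c1cnc(-c2ccc(C)s2)nc1NN1C(=O)C=C(C)C1=O` is not yet measured in this assay. It differs from compound 1 in one place: 5-methylthiophen-2-yl in place of methyl on an aromatic carbon.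

Two measured steps start from compound 1 and bear on this change. Extending the alkyl chain, a 1.6-fold lower number from compound 1 to compound 2 (0.20 log units; within the scatter), so a larger carbon group on its own gave no shift beyond the scatter. Exchanging the methyl for methylsulfanyl, an 80-fold lower number from compound 1 to compound 3 (1.90 log units; beyond the scatter), a large step; the same direction is seen in a 50-fold lower number from compound 2 to compound 3 (1.70 log units; beyond the scatter). Among the compounds with values here, the group entering in compound 4 is an aromatic ring that carries one sulfur, so it is neither a plain alkyl like compound 2 nor the methylsulfanyl of compound 3, and no measured pair tells how such a ring behaves here.

On balance a step toward a lower number is expected for compound 4, smaller than the step to compound 3 and with wide uncertainty, a 6.4-fold lower number from compound 1 to compound 4 (0.81 log units; beyond the scatter). Compound 4 is estimated at 2500 nM in this assay, within a range from 250 nM to 16000 nM.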

Compound 4, half-maximal inhibitory concentration: 200 nM
Compound 4: middle estimate off by 13-fold (1.10 log units), on the high side; the measured number lies below the stated range.
By their numbers in this assay, from the lowest: compounds 3 and 4 (each within the scatter of the next); then compounds 2 and 1 (each within the scatter of the next).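

At this place, between two ring nitrogen atoms, the large shift in this assay is not tied to methylsulfanyl: a group with one five-membered aromatic ring also gives an 80-fold lower number from compound 1 to compound 4 (1.90 log units; beyond the scatter) and a 50-fold lower number from compound 2 to compound 4 (1.70 log units; beyond the scatter). Going by these compounds alone, with no change at the digits printed from compound 3 to compound 4 (within the scatter), this assay does not separate 5-methylthiophen-2-yl from methylsulfanyl, although the two groups differ in size and only the former carries a ring, and across these four compounds the two sulfur-bearing groups give the lower numbers, with no compound going against this. No measured evidence on why these two groups behave alike is available for this series.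

The compounds shown leave open whether sulfur is the feature that matters, and phenyl or furan-2-yl at this place, or a longer sulfur-linked chain such as ethylsulfanyl, would bear on that. They also leave open what the methyl of the 5-methylthiophen-2-yl group contributes, which the same ring without that methyl would show.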